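Adding an amino group to a chloropurine cytotoxic series

This account rests on a few compounds, and the source may have more. Where it says the series, first, only, none or still open, it means among the compounds named here.

Of the compounds shown here, three sharing one core have been tested in a functional assay on 786-0 cells (Homo sapiens) for cytotoxicity, read by sulforhodamine B assay, with a stated time of 48 h; a lower number here means a stronger inhibitor of growth, a higher number a weaker inhibitor of growth. Compound 1 `ClCc1ccccc1Cn1cnc2c(Cl)nc(Cl)nc21` carries two chloro groups on its six-membered ring and gives 1860 nM. Compound 2 `ClCc1ccccc1Cn1cnc2c(Cl)ncnc21` keeps only one of them, and in this assay compound 2 gives 17800 nM. For the measured compounds named here, compound 3 `ClCc1ccccc1Cn1cnc2ncnc(Cl)c21`, with its single chloro group on a different carbon, gives 3980 nM in this assay. Compound 2 therefore stands at the highest number of the three, that is, as the weakest growth inhibitor among them; compound 3 gives a lower number, and compound 1 a lower one still.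

Going by the values given here, the one step that can be followed directly is a 9.6-fold higher number from compound 1 to compound 2 (0.98 log units; beyond the scatter), so removing a chloro group at that position made compound 2 a markedly weaker inhibitor.

Compound 4 `Nc1nc(Cl)c2ncn(Cc3ccccc3CCl)c2n1` returns to that same position, but with a different group: amino in place of hydrogen on an aromatic carbon. Among the compounds with values here, no measured compound carries an amino group there, so the only guide is that an occupied position in compound 1 gave 1860 nM while the bare position in compound 2 gave 17800 nM. On that basis a lower number than compound 2 is expected, though by less than the removal cost, since the group differs. Compound 4 is estimated at 6000 nM, with a range from 1500 nM to 25000 nM. The expected step is a 3.0-fold lower number from compound 2 to compound 4 (0.47 log units; beyond the scatter).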

Compound 4, concentration for 50% growth inhibition: 17000 nM
Beside the measured number, compound 4's estimate is 2.8-fold (0.45 log units) below it, and the stated range covers the measured number.
By their numbers in this assay, from the lowest: compound 1; then compound 3; then compounds 4 and 2 (each within the scatter of the next).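

In this assay, amino in place of hydrogen on the aromatic carbon between two ring nitrogen atoms gives a 1.0-fold lower number from compound 2 to compound 4 (0.02 log units; within the scatter) and so cannot be told apart from the bare position. Amino in place of chloro on that carbon gives a 9.1-fold higher number from compound 1 to compound 4 (0.96 log units; beyond the scatter) and is close in size to the earlier removal of the chloro group, a 9.6-fold higher number from compound 1 to compound 2 (0.98 log units; beyond the scatter) and so filling this position is not enough in itself: of the two groups shown there, only chloro goes with the lower number. Nothing measured here explains why chloro and amino part ways at this carbon.

From the compounds shown here alone, whether bromo or fluoro on this carbon would follow chloro, or whether methyl or methoxy would stay level with hydrogen and amino, remains open. For the compounds shown here, also open is whether an amino group here would behave the same way in the arrangement of compound 3 , where the single chloro group sits on a different carbon.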